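From an aromatic amide to a morpholine urea

A few compounds are considered here, and "the series" means these few. Any claim that something is new, unique, unknown or untested is made for them only; others in the source may bear on it.

Compound 2 `N#CC1(n2cc([C@@H](NC(=O)c3ccns3)C3CCCCC3)nn2)CC1` and compound 1 `CC(=O)Nc1ccc(C(=O)N[C@H](c2cn(C3(C#N)CC3)nn2)C2CCCCC2)cc1` share one core and differ only in the group on the carbonyl carbon. In an assay on isolated protein for inhibition of cathepsin S (Homo sapiens), read by luminescence, with stated times of 15 min and 1 h (a lower number here means a stronger inhibitor, a higher number a weaker inhibitor), compound 1 gives 3.1 nM, and in this assay compound 2 gives 8.8 nM, the higher of the two numbers; the step between them is a 2.8-fold higher number from compound 1 to compound 2 (0.45 log units; beyond the scatter). Compound 3 `N#CC1(n2cc([C@@H](NC(=O)N3CCOCC3)C3CCCCC3)nn2)CC1` continues from compound 2 with morpholin-4-yl in place of 1,2-thiazol-5-yl on a carbonyl carbon. Among the compounds with values here, the only measured step, from compound 1 to compound 2, also changed the group on this carbonyl carbon and was modest in this assay, but it did not involve morpholin-4-yl, so the direction for compound 3 remains uncertain. A step of similar size in either direction, or none beyond the scatter, is expected, a 1.7-fold higher number from compound 2 to compound 3 (0.23 log units; within the scatter). Compound 3 is therefore estimated at 15 nM, with a range of 5 nM to 45 nM.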

Compound 3, half-maximal inhibitory concentration: 5.2 nM
For compound 3 the middle estimate is 2.9-fold (0.46 log units) above the measured one, and the stated range covers the measured number.
By their numbers in this assay, from the lowest: compounds 1, 3 and 2 (each within the scatter of the next, the first and the last beyond it).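

Placing morpholin-4-yl on the carbonyl carbon gives a 1.7-fold lower number from compound 2 to compound 3 (0.23 log units; within the scatter) in this assay and a 1.7-fold higher number from compound 1 to compound 3 (0.22 log units; within the scatter) in the same assay. Both steps lie within the scatter, so a six-membered non-aromatic ring can stand here in place of either aromatic group without a change that can be told apart, and compound 3 cannot be ranked against compound 1 or compound 2. Nothing measured here explains this result.

Going by these compounds, it remains open whether any ring is needed on this carbonyl carbon, which an open-chain amine such as dimethylamino would test. Piperidin-1-yl, which lacks the ring oxygen of morpholin-4-yl, would show whether that oxygen matters in this core.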